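The compounds below may be only part of what the source reports. "The series", "measured", "known", "first", "only" and "open" are said of these compounds alone.

Measured compounds in an assay on CHO cells for displacement of a labelled ligand from adenosine receptor A3 (Homo sapiens), read by scintillation counting, with a stated time of 45 min, in the presence of a further agent that is not named here; on this read-out higher numbers stand for weaker inhibition and lower numbers for stronger inhibition:
Compound 1 `CCCn1c(=O)[nH]c2nc(-c3ccc(S(=O)(=O)N4CCN(c5ccccc5C)CC4)cc3)[nH]c2c1=O` gives a limit of the assay, > 1000 nM.
Compound 2 `CCCn1c(=O)[nH]c2nc(-c3ccc(S(=O)(=O)N4CCN(c5cccc(Cl)c5)CC4)cc3)[nH]c2c1=O` gives 53.5 nM.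
Compound 3 `CCCn1c(=O)[nH]c2nc(-c3ccc(S(=O)(=O)N4CCN(c5ccccc5F)CC4)cc3)[nH]c2c1=O` gives a limit of the assay, > 1000 nM.

Compound 3 therefore stands only at a limit in this assay, and it is not alone there: the limit of > 1000 nM in this assay, at which 2 of the 3 values shown sit. Compound 4 `CCCn1c(=O)[nH]c2nc(-c3ccc(S(=O)(=O)N4CCN(c5ccccc5Cl)CC4)cc3)[nH]c2c1=O` differs from compound 3 by chloro in place of fluoro on an aromatic carbon. Among the compounds with values here, no measured step repeats this exact change. The steps on the same ring are an at least 18-fold lower number from compound 1 to compound 2 (1.27 log units; beyond the scatter) and an at least 18-fold higher number from compound 2 to compound 3 (1.27 log units; beyond the scatter), both large, while a step that the two limits leave unreadable from compound 1 to compound 3. Compound 1 with 2-methylphenyl and compound 3 with 2-fluorophenyl both sit at the limit, so compound 4 with 2-chlorophenyl is expected to stay near it, with a step that the limit leaves unreadable from compound 3 to compound 4 expected to be small at most. Compound 4 is estimated at 1500 nM, between 300 nM and 8000 nM, and is expected to be reported most likely as a limit again.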

Compound 4, inhibition constant: > 1000 nM
Compound 4: only a limit was reported; the forecaster's own chance of this, stated with the estimate: 70%; the middle value does not contradict the limit.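

In this assay compound 4 gives > 1000 nM, which is a limit of the assay. With the same chloro group, 2-chlorophenyl in place of 3-chlorophenyl gives an at least 18-fold higher number from compound 2 to compound 4 (1.27 log units; beyond the scatter), so among these compounds the measured value depends on where the chloro sits and not only on its presence. The steps among compound 1, compound 3 and compound 4 cannot be read, as all three stand at the same limit: the limit of > 1000 nM in this assay, at which 3 of the 4 values shown sit.

On these data alone, how far these three lie past the limit stays open, as does how 4-chlorophenyl or 3-methoxyphenyl would compare with the 3-chlorophenyl of compound 2.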